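Amide-nitrogen substituent swap in a weakly active series

The source may hold more compounds than are shown below. What is called first, only, known or untested is meant among the compounds shown, and "the series" means these compounds.

Measured compounds:
compound 1 `COc1cccc(N2C(=O)COc3ccc(-c4cnc5ccccc5c4)cc32)c1`: 23600 nM
compound 2 `COc1ncc(-c2ccc3c(c2)NC(=O)CO3)cc1NS(=O)(=O)c1ccc(F)cc1`: 26300 nM
compound 3 `CC(C)N1C(=O)COc2ccc(-c3cccc(NS(=O)(=O)c4ccc(F)cc4)c3)cc21`: > 40000 nM

In a functional assay on A-375 cells (Homo sapiens) for antiproliferative activity, read by MTT assay, with a stated time of 72 h (on this read-out higher numbers stand for weaker inhibition and lower numbers for stronger inhibition), compound 1 gives 23600 nM and compound 2 gives 26300 nM; the two values lie within the scatter of each other, so no order between them is claimed. Compound 3 stands at the limit of this assay, (the limit of > 40000 nM in this assay, at which 1 of the 3 values shown sits), and no number is known for it. Nothing in the measured set is a single-point step, so no measured step size is available.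

Compound 4 `COc1cccc(N2C(=O)COc3ccc(-c4cccc(NS(=O)(=O)c5ccc(F)cc5)c4)cc32)c1` differs from compound 3 in one place: 3-methoxyphenyl in place of isopropyl on an amide-type nitrogen in a ring. Compound 1 carries the same 3-methoxyphenyl on the same amide-type nitrogen, with a different substituent on the fused core, and sits at a measured number rather than at the limit; compound 2 carries an unsubstituted amide-type nitrogen and also sits at a measured number. On this basis the step from compound 3 to compound 4 is expected to be small and, if anything, toward stronger inhibition, most likely within the scatter.

Compound 4 is expected to give 30000 nM in this assay, with a range of 12000 nM to 80000 nM, meaning an expected step of an at least 1.3-fold lower number from compound 3 to compound 4 (0.12 log units; that floor lies within the scatter).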

Compound 4, half-maximal inhibitory concentration: > 40000 nM
Compound 4 gave a limit, no number; the forecaster's own chance of this, stated with the estimate: 40%; middle value at least 1.3-fold (0.12 log units) away from the limit.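

In this assay, among the compounds shown here, compound 3 and compound 4 both stand at a limit rather than a number, so no step between them can be read: the limit of > 40000 nM in this assay, at which 2 of the 4 values shown sit. On these data alone, whether 3-methoxyphenyl in place of isopropyl on the amide-type nitrogen shifts inhibition at all stays open.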